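This account rests on a few compounds, and the source may have more. Where it says the series, first, only, none or still open, it means among the compounds named here.

Compound 1, whose structure is `COC(=O)N[C@H](C(=O)N1CCC[C@H]1C(=O)Nc1ccc([C@H]2CC[C@H](c3ccc(NC(=O)[C@@H]4CCCN4C(=O)[C@@H](NC(=O)OC)C(C)C)cc3)N2c2ccc(C(F)(F)F)cc2)cc1)C(C)C`, was examined in an ADME assay on the whole organism for pharmacokinetics, with Canis familiaris (Canis lupus familiaris) as the target, at a dose of 2.5 mg/kg by the oral route (a lower number here means less compound in the circulation, a higher number more compound in the circulation at the dose given), and gives 55.2 nM. Of the two compounds measured, this is the lowest number. The only comparator, compound 2, has the structure `COC(=O)N[C@H](C(=O)N1CCC[C@H]1C(=O)Nc1ccc([C@H]2CC[C@H](c3ccc(NC(=O)[C@@H]4CCCN4C(=O)[C@@H](NC(=O)OC)C(C)(C)C)cc3)N2c2ccc(F)cc2)cc1)C(C)(C)C` and gives 1210 nM in this assay, a gap that lies well beyond the usual scatter; compound 2 differs from compound 1 in more than one place, so nothing beyond the two values themselves can be read from that pair. Compound 3, with the structure `COC(=O)N[C@H](C(=O)N1CCC[C@H]1C(=O)Nc1ccc([C@H]2CC[C@H](c3ccc(NC(=O)[C@@H]4CCCN4C(=O)[C@@H](NC(=O)OC)C(C)C)cc3)N2c2ccc(F)cc2)cc1)C(C)C`, has not yet been measured in this assay. It departs from compound 1 in a single spot: fluoro in place of trifluoromethyl on an aromatic carbon. The 4-fluorophenyl is the same group found in compound 2. On that basis, the number for compound 3 is expected to move upward, a step of a 5.4-fold higher number from compound 1 to compound 3 (0.74 log units; beyond the scatter), with wide uncertainty since no single-change comparison exists here. The estimate for compound 3 is 300 nM, with a range from 80 nM to 1200 nM.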

Compound 3, maximal plasma concentration: 491 nM
Beside the measured number, compound 3's estimate is 1.6-fold (0.21 log units) below it; low and high end bracket the measured number.
By their numbers in this assay, from the lowest: compound 1; then compound 3; then compound 2.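

In this assay, replacing the 4-(trifluoromethyl)phenyl with 4-fluorophenyl gives an 8.9-fold higher number from compound 1 to compound 3 (0.95 log units; beyond the scatter). Going by these compounds alone, this is the first comparison here in which only one place changes, so this step can be tied to that place, on an aromatic carbon para to a large group, whereas the earlier gap involving compound 2 could not be tied to any single change. The result shows that this one substituent can shift the peak level of compound in the dog's blood by more than repeat measurements would, but nothing available explains why the change has this effect.

Within the data shown here, with only one pair at this position, it remains open how other groups there, such as chloro, methoxy or nitrile, would compare with fluoro and trifluoromethyl. As far as these compounds go, it is also open whether the same swap would give a step of similar size in compounds carrying the tert-butyl groups of compound 2 rather than the isopropyl groups of compound 1 and compound 3.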